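Swapping the pyridyl arm for fluorophenyl in a cytotoxicity screen

The compounds below may be only part of what the source reports. "The series", "measured", "known", "first", "only" and "open" are said of these compounds alone.

Compound 1 `Cn1c(Cc2ccccc2C(F)(F)F)nc(C(=O)NCc2cccnc2)c(O)c1=O` was tested in an ADME assay on HepG2 cells (Homo sapiens) for cytotoxicity, in the presence of a further agent that is not named here; on this read-out lower numbers stand for stronger inhibition and higher numbers for weaker inhibition. In this assay compound 1 gives > 100000 nM, which is a limit of the assay rather than a number. Compound 2 `COc1nc(C(C)c2ccccc2C(F)(F)F)nc(C(=O)NCc2ccccc2)c1O` gives > 100000 nM, again a limit. The picture so far is the limit of > 100000 nM in this assay, at which 2 of the 2 values shown sit. Compound 3 `Cn1c(Cc2ccccc2C(F)(F)F)nc(C(=O)NCc2ccc(F)cc2)c(O)c1=O` has not yet been measured; it differs from compound 1 by 4-fluorophenyl in place of pyridin-3-yl on a saturated chain carbon bound to an amide-type nitrogen. Going by the values given here, no step between measured compounds exists to draw on, so no shift beyond the usual scatter is expected. Compound 3 is expected to give 100000 nM, with a range from 30000 nM to 100000 nM. Compound 3 thus carries an expected a number no higher from compound 1 to compound 3 (the limit leaves the size open) of essentially nothing.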

Compound 3, half-maximal inhibitory concentration: > 100000 nM
Compound 3 was reported as a limit; the forecaster's own chance of this, stated with the estimate: 85%; the middle value lies on the limit itself.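

In this assay compound 3 gives > 100000 nM, a limit of the assay and not a number. Going by these compounds alone, compound 1 also stands at a limit, and no step from compound 1 to compound 3 can be read. The compounds shown leave open whether 4-fluorophenyl in place of pyridin-3-yl changes this read-out at all.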